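Chain variation on the shared core, toward compound 4

A few compounds are considered here, and "the series" means these few. Any claim that something is new, unique, unknown or untested is made for them only; others in the source may bear on it.

Measured compounds and values in an assay on CHO-K1 cells for inhibition of 11-beta-hydroxysteroid dehydrogenase type 2 (Mus musculus), read by scintillation proximity assay; on this read-out higher numbers stand for weaker inhibition and lower numbers for stronger inhibition:
Compound 1, `Cn1c(-c2ccccc2C(F)(F)F)nnc1C12CCC(CCCC(C)(F)F)(CC1)CC2`: compound 1 gives > 4000 nM, a limit of the assay.
Compound 2, `CC(C)S(=O)(=O)CCC12CCC(c3nnc(-c4ccccc4C(F)(F)F)n3C)(CC1)CC2`: compound 2 gives > 4000 nM, also a limit.
Compound 3, `CCCCCC12CCC(c3nnc(-c4ccccc4C(F)(F)F)n3C)(CC1)CC2`: compound 3 gives > 4000 nM, again a limit.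

Compound 3 thus stands at the limit, and so do the other two; none of the three values is a number, so no ranking among them can be drawn. Going by the values given here, the single piece of evidence is the limit of > 4000 nM in this assay, at which 3 of the 3 values shown sit. The steps connecting the measured compounds are a step that the two limits leave unreadable from compound 1 to compound 2, a step that the two limits leave unreadable from compound 1 to compound 3 and a step that the two limits leave unreadable from compound 2 to compound 3; with both ends of each pair at the limit, their size cannot be read.

Compound 4, `CC(F)CCCC12CCC(c3nnc(-c4ccccc4C(F)(F)F)n3C)(CC1)CC2`, differs from compound 3 by fluoro in place of hydrogen on a saturated chain carbon bound to two saturated chain carbons. Among the compounds with values here, no measured step concerns this change; the three measured steps involve other chain variants and are all unreadable. With every chain variant so far at the limit, no step beyond the scatter is anticipated, and the most likely outcome is another limit rather than a number. Compound 4 is therefore expected at 8000 nM, with a range of 3000 nM to 30000 nM. The corresponding step is expected at a step that the limit leaves unreadable from compound 3 to compound 4.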

Compound 4, half-maximal inhibitory concentration: > 4000 nM
Compound 4: a limit, no number (the forecaster's own chance of this, stated with the estimate: 85%); the middle value lies beyond the limit too.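

Compound 4 joins compound 1, compound 2 and compound 3 at the limit in this assay, so no step among these compounds can be read: the limit of > 4000 nM in this assay, at which 4 of the 4 values shown sit.

The compounds shown leave open whether any chain on the shared core gives a number rather than a limit on this read-out, and how large the step from hydrogen to fluoro would then be.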